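A Bromo for Fluoro Swap on Compound 1

This account rests on a few compounds, and the source may have more. Where it says the series, first, only, none or still open, it means among the compounds named here.

For the measured compounds named here, compound 1 `COc1cc(CCc2ccc(F)cc2)cc(OC)c1O` was tested in a functional assay on MKN-45 cells (Homo sapiens) for antiproliferative activity, read by MTT assay, with a stated time of 72 h (a higher number here means a weaker inhibitor, a lower number a stronger inhibitor), where compound 1 gives 10700 nM; of the two numbers measured so far, this is the highest. Compound 2 `COc1cc(CCc2cccc(Cl)c2Cl)cc(OC)c1O`, which carries chloro groups rather than a fluoro, gives 11 nM in this assay, a far lower number than compound 1. Compound 3 `COc1cc(CCc2ccc(Br)cc2)cc(OC)c1O` differs from compound 1 by bromo in place of fluoro on an aromatic carbon. Going by the values given here, no measured pair isolates this swap, so the expected step, a 3.6-fold lower number from compound 1 to compound 3 (0.55 log units; beyond the scatter), is a moderate fall in the number, well beyond the scatter but far short of the gap to compound 2. Compound 3 is expected to give 3000 nM in this assay, within 600 nM to 12000 nM.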

Compound 3, half-maximal inhibitory concentration: 1490 nM
For compound 3 the middle estimate is 2.0-fold (0.30 log units) above the measured one; low and high end bracket the measured number.
By their numbers in this assay, from the lowest: compound 2; then compound 3; then compound 1.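

Changing only the fluoro to a bromo, para to a large group, gives a 7.2-fold lower number from compound 1 to compound 3 (0.86 log units; beyond the scatter) in this assay, so this position on the aromatic ring responds to which halogen it carries. This exchange of one atom for another adds no ring, hydrogen-bond donor or hydrogen-bond acceptor. Nothing available here explains why the bromo gives the lower number. Open, as far as these compounds go, is how an amine or a carboxylic acid at this place would compare with the bromo. Also open, from the compounds shown here alone, is whether the same swap elsewhere on the ring would give a similar step.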